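This account rests on a few compounds, and the source may have more. Where it says the series, first, only, none or still open, it means among the compounds named here.

In an ADME assay on J774.A1 cells (Mus musculus) for inhibition, read by MTT assay, with a stated time of 72 h (on this read-out higher numbers stand for an effect only at larger amounts of compound and lower numbers for an effect already at smaller amounts), the measured compounds stand as follows:
Compound 1 `COc1ccc(CNc2nc(NCc3ccccc3)nc3ccccc23)cc1` gives 5200 nM
Compound 2 `CNc1nc(NC)c2ccccc2n1` gives > 133000 nM (a limit of the assay, not a number)
Compound 3 `CNc1nc(NCc2ccco2)c2ccccc2n1` stands as "not determined" (no result reported)

Compound 3 therefore offers no number from which to step. Compound 4 `c1coc(CNc2nc(NC3CCCCC3)nc3ccccc23)c1` is still unmeasured. The change is cyclohexyl in place of methyl on a nitrogen on an aromatic ring. Among the compounds with values here, no measured step sets its size. Against the methyl groups of compound 2, compound 1 carries larger groups on the shared core and gives 5200 nM in this comparison. A sizeable move towards lower numbers in this assay is therefore expected, rather than none. The value estimated for compound 4 is 9000 nM within an expected range of 2500 nM to 35000 nM for now.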

Compound 4, half-maximal effective concentration: 5300 nM
The estimate for compound 4 lay 1.7-fold (0.23 log units) above the measured number; measured number inside the range.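

Compound 3 stands without a number in this assay, and no step to compound 4 can be read, nor does anything shown bear on this result. The compounds shown leave open what cyclohexyl in place of methyl does to the read-out.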